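Acid to benzylamide at the chain carbonyl of one core

This account rests on a few compounds, and the source may have more. Where it says the series, first, only, none or still open, it means among the compounds named here.

Compound 1 `O=C(O)CC1c2ccccc2N=C(N2CCCCC2)N1c1ccccc1` and compound 2 `CN1CCN(C2=Nc3ccccc3C(CC(=O)O)N2c2ccccc2)CC1` share one core and differ only at the carbon with a double bond to nitrogen. In a functional assay on cells (Oocyte) for inhibition of Voltage-dependent T-type calcium channel subunit alpha-1H (Homo sapiens), tested at 100 uM (a higher number here means more inhibition at the concentration tested (going by the name of the read-out), a lower number less inhibition), compound 1 gives 8% and compound 2 gives 15%. The step of a number 7 percentage points higher from compound 1 to compound 2 (within the scatter) lies within the scatter, so compound 1 carries the smaller bare figure of the two but the two numbers are not distinguished. Compound 3 `O=C(CC1c2ccccc2N=C(N2CCCCC2)N1c1ccccc1)NCc1ccccc1` is not yet measured; it differs from compound 1 by benzylamino in place of hydroxy on a carbonyl carbon. Among the measured compounds shown here, no measured step touches the carbonyl carbon: the only known step alters the carbon with a double bond to nitrogen and stays within the scatter, so it offers no guide to the present change. The expected step of a number 4 percentage points higher from compound 1 to compound 3 (within the scatter) is therefore unanchored, and no step beyond the scatter is expected. For compound 3 the estimate in this assay is 12%, with a range from 0% to 35%.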

Compound 3, a percentage reported as inhibition, at one concentration (the size of the read-out at that concentration, not a potency): 77%
For compound 3 the middle estimate is 65 percentage points below the measured one, outside the stated range (above it).
By their numbers in this assay, from the lowest: compounds 1 and 2 (each within the scatter of the next); then compound 3.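

Working from the carbonyl carbon of the shared core, benzylamino in place of hydroxy gives in this assay a number 69 percentage points higher from compound 1 to compound 3 (beyond the scatter) and is the only step shown that lies beyond the scatter. Among the compounds shown here, the one earlier step, at the carbon with a double bond to nitrogen, stayed within the scatter, so the carbonyl carbon is the only place in these compounds where a change has been seen to alter inhibition at the concentration tested. Nothing available explains the size of this step.

On these data alone, whether the step depends on the amide link or on the benzyl group remains open, and comparison with a primary amide, a methylamide or a benzyl ester at this carbonyl carbon would separate the two. Also open, as far as these compounds go, is whether the same change carries over to the 4-methylpiperazin-1-yl compound.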